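Alkyl variation on the shared core: the isobutyl analogue

The source may report more compounds than this note shows. Statements on the series, on what has been measured and on what is new or still open speak of the compounds shown alone.

The series keeps the shared core of compound 1 `CCCCOC(=O)NS(=O)(=O)c1ccc(CCC)cc1-c1ccc(Cn2c(C(C)(C)C)nc3ccccc32)cc1` and varies the group on an aromatic carbon. Within the data shown here, in an assay on membranes from HEK293 cells for displacement of a labelled ligand from Type-2 angiotensin II receptor (Homo sapiens), read by radioligand binding (a lower number here means a stronger inhibitor, a higher number a weaker inhibitor), compound 1 gives 5.3 nM, the lowest of the two numbers measured so far. Among the measured compounds shown here, compound 2 `CCCCOC(=O)NS(=O)(=O)c1ccc(CCC)cc1-c1ccc(Cn2c(CCC)nc3ccccc32)cc1` carries propyl in place of tert-butyl on an aromatic carbon; in this assay compound 2 gives 14 nM, and the step of a 2.6-fold higher number from compound 1 to compound 2 (0.42 log units; beyond the scatter) is the only measured step that bears on the present question.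

Compound 3 `CCCCOC(=O)NS(=O)(=O)c1ccc(CCC)cc1-c1ccc(Cn2c(CC(C)C)nc3ccccc32)cc1` is the next member: isobutyl in place of tert-butyl on an aromatic carbon. For the measured compounds named here, the one relevant step, from the branched tert-butyl to the unbranched propyl, raised the number modestly. Isobutyl, like tert-butyl, is a branched four-carbon group, yet like propyl it is not branched at its first carbon; the outcome is therefore expected to fall between keeping tert-butyl and moving to propyl, a small rise in this assay at or near the edge of the scatter. Compound 3 is expected to give 9 nM in this assay, within 4 nM to 20 nM. The estimated shift is a 1.7-fold higher number from compound 1 to compound 3 (0.23 log units; within the scatter).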

Compound 3, inhibition constant: 19 nM
Estimate against measurement, compound 3: 2.1-fold (0.32 log units) below, and the stated range covers the measured number.
By their numbers in this assay, from the lowest: compound 1; then compounds 2 and 3 (each within the scatter of the next).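

In this assay, the step of a 3.6-fold higher number from compound 1 to compound 3 (0.55 log units; beyond the scatter) shows that this position, on an aromatic carbon between two ring nitrogen atoms, responds to the arrangement of its carbons alone: tert-butyl and isobutyl both have 4 heavy atoms, all carbon, and neither has a ring. The step of a 1.4-fold higher number from compound 2 to compound 3 (0.13 log units; within the scatter) adds that a methyl in place of hydrogen on the saturated chain does not separate isobutyl from propyl, so compound 1 is the most potent of the three, with its steps to both others beyond the scatter. Nothing on hand explains the gap between tert-butyl and the other two groups.

With tert-butyl the only group here that is branched at the carbon on the ring, these compounds leave open whether that branching goes with the lower number, a question that isopropyl or cyclopropyl at the same place would address. Also open, from the compounds shown here alone, is how a longer chain such as pentyl, or an amine at this position, would compare with tert-butyl on the shared core.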